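Cyclohexyl in Place of Benzyl: Expected Cell Tolerance

The compounds below may be only part of what the source reports. "The series", "measured", "known", "first", "only" and "open" are said of these compounds alone.

Of the compounds shown here, three have been measured in an ADME assay on Huh-7 cells (Homo sapiens) for cytotoxicity; a higher number here means that more compound is tolerated, a lower number that less compound is tolerated. Compound 1 `Cc1ccccc1-c1nn(-c2ccc(F)cc2F)cc1CNCCN1CCCCC1` gives only a limit, > 20000 nM, so no number is known for it. Compound 2 `CN1CCN(CCNCc2cn(-c3ccc(F)cc3F)nc2Cc2ccccc2)CC1` likewise gives only a limit, > 20000 nM. Compound 3 `CN1CCN(CCNCc2cn(-c3ccc([N+](=O)[O-])cc3)nc2-c2ccc(C(F)(F)F)cc2)CC1` gives an actual number, 3200 nM. Compound 2 therefore stands at the limit of > 20000 nM in this assay, at which 2 of the 3 values shown sit; its value is a boundary of what the test can report rather than a measured point, and compound 3 is the only one of the three whose toxicity falls inside the tested window.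

Compound 4 `CN1CCN(CCNCc2cn(-c3ccc(F)cc3F)nc2C2CCCCC2)CC1` has not yet been measured. It differs from compound 2 in one place: cyclohexyl in place of benzyl on an aromatic carbon. Within the data shown here, no measured pair of compounds shows this change in this assay, so no step size can be read from the data. The expected change, a step that the limit leaves unreadable from compound 2 to compound 4, is nothing beyond the usual scatter, with a good chance that the test again reports only a limit. Compound 4 is accordingly estimated at 25000 nM, with a range from 8000 nM to 60000 nM.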

Compound 4, half-maximal cytotoxic concentration: > 20000 nM
Compound 4: no number, only a limit (the forecaster's own chance of this, stated with the estimate: 70%); the middle value does not contradict the limit.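

In this assay compound 2 and compound 4 each give only a limit, so no step can be read for cyclohexyl in place of benzyl. The compounds shown leave open how much compound is actually tolerated for either one, and whether this change alters that tolerance at all.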